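Swapping the halogenated benzyl group of compound 2 for methoxybenzyl

A few compounds are considered here, and "the series" means these few. Any claim that something is new, unique, unknown or untested is made for them only; others in the source may bear on it.

For the measured compounds named here, compound 2 `CCCn1c(=O)c2nc(-c3cnn(Cc4cc(F)ccc4Cl)c3)[nH]c2n(CCC)c1=O` gives the higher of the two numbers known so far: in an in vitro assay on HEK293 cells for displacement of a labelled ligand from adenosine receptor A2b (Homo sapiens) (on this read-out lower numbers stand for stronger inhibition and higher numbers for weaker inhibition), compound 2 shows 4800 nM, whereas compound 1 `CCCn1c(=O)c2nc(-c3cnn(Cc4ccc(F)cc4F)c3)[nH]c2n(CCC)c1=O` gives 700 nM. Going by the values given here, the single measured step is a 6.9-fold higher number from compound 1 to compound 2 (0.84 log units; beyond the scatter). That step concerns the group on a saturated chain carbon bound to an aromatic nitrogen. Compound 3 `CCCn1c(=O)c2nc(-c3cnn(Cc4ccccc4OC)c3)[nH]c2n(CCC)c1=O` differs from compound 2 at that same place: 2-methoxyphenyl in place of 2-chloro-5-fluorophenyl on a saturated chain carbon bound to an aromatic nitrogen. Among the compounds with values here, no measured step contains a methoxyphenyl there, so the only guide is that exchanging this group once shifted the number modestly. The expected step is a 2.7-fold lower number from compound 2 to compound 3 (0.43 log units; beyond the scatter). Compound 3 is therefore estimated at 1800 nM, with a range from 400 nM to 8000 nM.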

Compound 3, inhibition constant: 37 nM
Beside the measured number, compound 3's estimate is 49-fold (1.69 log units) above it; measured number below the stated range.
By their numbers in this assay, from the lowest: compound 3; then compound 1; then compound 2.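

In this assay, the group on a saturated chain carbon bound to an aromatic nitrogen turns out to matter far more than the halogen exchange alone showed: 2-methoxyphenyl gives a 130-fold lower number from compound 2 to compound 3 (2.11 log units; beyond the scatter) and a 19-fold lower number from compound 1 to compound 3 (1.28 log units; beyond the scatter). Compound 3 is thus the strongest of the three, although the group entering has the same count of heavy atoms as 2-chloro-5-fluorophenyl. No measurement here accounts for this gain. Going by these compounds, whether it comes from gaining the methoxy group or from losing the halogens stays open, as does how a plain benzyl or an ethoxy group would compare.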